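The compounds below may be only part of what the source reports. "The series", "measured", "known", "first", "only" and "open" are said of these compounds alone.

Compound 1 `Cc1nc(C(NC(=O)C(=O)Nc2ccc(F)c(F)c2)C2CCCCN2)sc1CO` is one of two close relatives that have been tested for how well cells tolerate them. In an ADME assay on TZM-b1 cells (Homo sapiens) for cytotoxicity, read by XTT assay, with a stated time of 3 days (a higher number here means that more compound is tolerated, a lower number that less compound is tolerated), compound 1 gives > 87000 nM, which is a limit of the assay rather than a measured number. Compound 2 `Cc1nc(C(NC(=O)C(=O)Nc2ccc(F)cc2)C2CCCCN2)sc1CCO` has been tested the same way. In this assay compound 2 gives > 88000 nM, again a limit and not a number. So compound 1 stands at a limit, and the one other value known sits at a limit as well the limit of > 87000 nM in this assay, at which 1 of the 2 values shown sits (the limit of > 88000 nM in this assay, at which 1 of the 2 values shown sits). Compound 3 `Cc1nc(C(NC(=O)C(=O)Nc2ccc(F)cc2F)C2CCCCN2)sc1CO` has not yet been tested. It differs from compound 1 by a single rearrangement (2,4-difluorophenyl in place of 3,4-difluorophenyl on an amide-type nitrogen). Both measured compounds sit at limits, so no step is expected beyond the scatter, and the step is estimated as a step that the limit leaves unreadable from compound 1 to compound 3. For compound 3 the expected value in this assay is 90000 nM, within a range from 45000 nM to 180000 nM.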

Compound 3, half-maximal cytotoxic concentration: > 87000 nM
Compound 3: only a limit was reported; the forecaster's own chance of this, stated with the estimate: 80%; the middle value does not contradict the limit.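

No step can be read between compound 1 and compound 3, because both values are a limit of the assay and not a number: the limit of > 87000 nM in this assay, at which 2 of the 3 values shown sit. The compounds shown leave open at what concentration any of them starts to harm these cells, and whether 2,4-difluorophenyl in place of 3,4-difluorophenyl changes that at all.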